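The source may report more compounds than this note shows. Statements on the series, on what has been measured and on what is new or still open speak of the compounds shown alone.

Measured compounds in an assay for binding affinity to Melanocortin receptor 4 (Homo sapiens); on this read-out lower numbers stand for stronger inhibition and higher numbers for weaker inhibition:
- compound 1 `COc1ccc(Br)cc1CCc1c(F)cccc1C(=O)/N=C(\N)NCC1CCNCC1`: 13 nM
- compound 2 `COc1ccc(Br)cc1CCc1c(F)cccc1C(=O)/N=C(\N)NCCCN1CCCCC1`: 3.2 nM
- compound 3 `COc1ccc(Br)cc1CCc1c(F)cccc1C(=O)/N=C(\N)NCCN1CCCC1`: 190 nM

Compound 3 stands highest of the three in this assay, separated from compound 1 by a 15-fold higher number from compound 1 to compound 3 (1.16 log units; beyond the scatter) and from compound 2 by a 59-fold higher number from compound 2 to compound 3 (1.77 log units; beyond the scatter), both beyond the scatter.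

Compound 4 `COc1ccc(Br)cc1CCc1c(F)cccc1C(=O)/N=C(\N)NCCCN1CCN(C)CC1` differs from compound 3 by (4-methylpiperazin-1-yl)methyl in place of pyrrolidin-1-yl on a saturated chain carbon, two bonds along the chain from an amine nitrogen. The step bearing most directly on it runs the other way: a 59-fold higher number from compound 2 to compound 3 (1.77 log units; beyond the scatter). Going by the values given here, compound 4 restores a six-membered ring one bond further out, as in compound 2, though with a second nitrogen carrying a methyl group, for which no step exists. Among the compounds with values here, a large drop in the number is therefore expected, with a 24-fold lower number from compound 3 to compound 4 (1.38 log units; beyond the scatter), probably not reaching compound 2 because compound 2 gives 3.2 nM with a ring that differs from the one in compound 4. Compound 4 is estimated at 8 nM, range 2 nM to 40 nM.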

Compound 4, inhibition constant: 64 nM
Compound 4: the middle estimate sits 8.0-fold (0.90 log units) below what was measured, and the stated range ends below it.
By their numbers in this assay, from the lowest: compound 2; then compound 1; then compound 4; then compound 3.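

In this assay the ring itself matters at this place, not only its size and its distance along the chain: with the chain of compound 2 kept, 4-methylpiperazin-1-yl in place of piperidin-1-yl costs much of the binding (a 20-fold higher number from compound 2 to compound 4 (1.30 log units; beyond the scatter)). Moving from pyrrolidin-1-yl to (4-methylpiperazin-1-yl)methyl gains only a modest amount (a 3.0-fold lower number from compound 3 to compound 4 (0.47 log units; beyond the scatter)), and 2-(4-methylpiperazin-1-yl)ethyl also falls behind piperidin-4-yl (a 4.9-fold higher number from compound 1 to compound 4 (0.69 log units; beyond the scatter)). No supporting measurement accounts for these differences.

Still open, going by these compounds, is where a morpholin-4-yl or an unsubstituted piperazin-1-yl would fall on the same chain, which would separate the second ring nitrogen from its methyl group.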